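A few compounds are considered here, and "the series" means these few. Any claim that something is new, unique, unknown or untested is made for them only; others in the source may bear on it.

Compound 1, `CCNc1cc(-c2ccc(NC(=O)Nc3ccc(C)cc3)cc2C)ccn1`, gives 47.5% in an assay on isolated protein for inhibition of serine/threonine-protein kinase PLK1 (Homo sapiens), read by radiometric assay and 33P incorporation, with a stated time of 40 min, tested at 20 uM, in the presence of a further agent that is not named here; a higher number here means more inhibition at the concentration tested (going by the name of the read-out), a lower number less inhibition.
Compound 2, `CCNc1cc(-c2ccc(NC(=O)Nc3ccccc3Cl)cc2C)ccn1`, gives 49.2% in this assay.
Compound 3, `CCNc1cc(-c2ccc(NC(=O)Nc3ccc(C)cc3)cc2C(F)(F)F)ccn1`, gives 42.6% in this assay.

Compound 3 has the lowest of the three numbers, yet its distance to compound 1, the nearest, and to compound 2, the furthest, are both within the scatter of this kind of measurement, so the three compounds cannot be told apart on these numbers. Compound 4, `CCNc1cc(-c2ccc(NC(=O)Nc3ccc(C(F)(F)F)cc3)cc2C(F)(F)F)ccn1`, is not yet measured. It differs from compound 3 in one place: trifluoromethyl in place of methyl on an aromatic carbon. For the measured compounds named here, two measured steps bear on this. The step of a number 4.9 percentage points lower from compound 1 to compound 3 (within the scatter) is the same kind of change, though at another place in the molecule, and the step of a number 1.7 percentage points higher from compound 1 to compound 2 (within the scatter) shows that altering the group on the urea nitrogen also left the number where it was. Neither points to a step beyond the scatter in this assay for compound 4. The expected step is therefore a number 0.6 percentage points lower from compound 3 to compound 4 (within the scatter). Compound 4 is estimated at 42%, within a range from 26% to 58%.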

Compound 4, a percentage reported as inhibition, at one concentration (the size of the read-out at that concentration, not a potency): 82.9%
For compound 4 the middle estimate is 40.9 percentage points below the measured one, and the stated range ends below it.
By their numbers in this assay, from the lowest: compounds 3, 1 and 2 (each within the scatter of the next); then compound 4.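

In this assay, trifluoromethyl in place of methyl on this aromatic carbon, para to a large group, gives a number 40.3 percentage points higher from compound 3 to compound 4 (beyond the scatter) and is the only step shown that lies beyond the scatter. The same exchange at another place in the molecule gives a number 4.9 percentage points lower from compound 1 to compound 3 (within the scatter), so among these compounds the outcome of this change depends on where it is made. No measurement shown accounts for the size of this step.

The compounds shown leave open whether a nitrile or a methoxy group at this position would give a similar number, or whether the result is particular to trifluoromethyl. They also leave open whether trifluoromethyl here would give such a step with methyl, rather than trifluoromethyl, at the other place in the molecule.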